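A few compounds are considered here, and "the series" means these few. Any claim that something is new, unique, unknown or untested is made for them only; others in the source may bear on it.

Working notes on the series. For the measured compounds named here, the shared core carries an acrylamide-bearing aryl amide linked through a thioether to a bicyclic heteroaromatic unit, which in turn bears an arylamino group; only that aryl group varies. Compound 1 `C=CC(=O)Nc1cccc(NC(=O)CSc2nc(Nc3ccccc3Cl)c3ccccc3n2)c1` gives 20700 nM in a functional assay on MGC-803 cells (Homo sapiens) for inhibition, read by MTT assay, with a stated time of 72 h; on this read-out higher numbers stand for weaker inhibition and lower numbers for stronger inhibition. Compound 2 `C=CC(=O)Nc1cccc(NC(=O)CSc2nc(Nc3cccc(Cl)c3)c3ccccc3n2)c1` gives 7830 nM in this assay, and compound 3 `C=CC(=O)Nc1cccc(NC(=O)CSc2nc(Nc3ccc(F)cc3)c3ccccc3n2)c1` gives 8290 nM. On these three numbers compound 3 stands second highest; its nearest neighbour is compound 2, and a 1.1-fold higher number from compound 2 to compound 3 (0.02 log units; within the scatter) is within the scatter, while a 2.5-fold lower number from compound 1 to compound 3 (0.40 log units; beyond the scatter) is beyond it. Going by the values given here, likewise a 2.6-fold lower number from compound 1 to compound 2 (0.42 log units; beyond the scatter) is beyond the scatter, so 2-chlorophenyl is the one group here that gives a clearly higher number.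

Compound 4 `C=CC(=O)Nc1cccc(NC(=O)CSc2nc(Nc3ccc(Cl)cc3Cl)c3ccccc3n2)c1` is not yet measured in this assay. The change from compound 3 is 2,4-dichlorophenyl in place of 4-fluorophenyl on a nitrogen on an aromatic ring. The entering group combines a chlorine at the position of the 4-fluorophenyl substituent with a chlorine at the position that in compound 1 went with the highest number, so the bearing steps are a 2.5-fold lower number from compound 1 to compound 3 (0.40 log units; beyond the scatter) and a 1.1-fold higher number from compound 2 to compound 3 (0.02 log units; within the scatter). A modest upward step is therefore expected, with a 1.6-fold higher number from compound 3 to compound 4 (0.20 log units; within the scatter) as the estimate, and compound 4 is expected near 13000 nM (range 5000 nM to 32000 nM).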

Compound 4, half-maximal inhibitory concentration: 12100 nM
For compound 4 the middle estimate is 1.1-fold (0.03 log units) above the measured one; the measured number falls inside the stated range.
By their numbers in this assay, from the lowest: compounds 2, 3, 4 and 1 (each within the scatter of the next, the first and the last beyond it).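

In this assay, the 2,4-dichlorophenyl group of compound 4 adds chloro in place of hydrogen on an aromatic carbon of the 2-chlorophenyl group of compound 1, and this gives a 1.7-fold lower number from compound 1 to compound 4 (0.23 log units; within the scatter), so this change does not clear the scatter. The other two steps, a 1.5-fold higher number from compound 3 to compound 4 (0.16 log units; within the scatter) and a 1.5-fold higher number from compound 2 to compound 4 (0.19 log units; within the scatter), are also within the scatter, which leaves compound 4 not separable from any of the other three compounds, although compound 1 stays separable from compound 2 and compound 3. No measured property bears on these steps, so they stand without an explanation.

Every aryl group shown carries only chloro or fluoro, so it remains open whether a methoxy group, an amine or a carboxylic acid on that ring would move the number beyond the scatter. Going by these compounds, the acrylamide is common to all four compounds, so what a saturated propanamide in its place would give also stays open.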